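This account rests on a few compounds, and the source may have more. Where it says the series, first, only, none or still open, it means among the compounds named here.

Measured compounds and their values in a functional assay on PC-3 cells (Homo sapiens) for cytotoxicity, read by sulforhodamine B assay, with a stated time of 72 h; on this read-out higher numbers stand for weaker inhibition of growth and lower numbers for stronger inhibition of growth:

compound 1, `O=C(Nc1cc(C(F)(F)F)cc(C(F)(F)F)c1)C1CCc2ccccc2N1C(=O)c1ccc(Cl)cc1`, gives 4230 nM
compound 2, `O=C(Nc1cc(C(F)(F)F)cc(C(F)(F)F)c1)C1CCc2ccccc2N1C(=O)c1cccc(Cl)c1`, gives 1050 nM
compound 3, `O=C(Nc1ccccc1C(F)(F)F)C1CCc2ccccc2N1C(=O)c1ccccc1Cl`, gives 5140 nM

Compound 2 has the lowest number of the three; compound 1 is the nearest to it, and the step of a 4.0-fold lower number from compound 1 to compound 2 (0.61 log units; beyond the scatter) lies beyond the usual scatter. Compound 3, which differs from compound 2 in more than one place, gives a number higher than compound 2 by a margin also beyond the scatter.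

Compound 4, `CCCC(=O)N1c2ccccc2CCC1C(=O)Nc1cc(C(F)(F)F)cc(C(F)(F)F)c1`, is not yet measured. It differs from compound 2 in one place: propyl in place of 3-chlorophenyl on a carbonyl carbon. Among the measured compounds shown here, no measured step bears directly on this change; the only single-site step, from compound 1 to compound 2, moves a chlorine on a ring that here disappears entirely. The step in this assay is therefore expected to go toward a higher number, of uncertain size, and the value for compound 4 is estimated at 3500 nM, within 900 nM to 14000 nM, so that the expected step is a 3.3-fold higher number from compound 2 to compound 4 (0.52 log units; beyond the scatter).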

Compound 4, concentration for 50% growth inhibition: 18600 nM
Beside the measured number, compound 4's estimate is 5.3-fold (0.73 log units) below it; measured number above the stated range.
By their numbers in this assay, from the lowest: compound 2; then compounds 1 and 3 (each within the scatter of the next); then compound 4.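

In this assay, propyl in place of a chlorophenyl group on this carbonyl carbon gives weaker growth inhibition with either chlorine placement: an 18-fold higher number from compound 2 to compound 4 (1.25 log units; beyond the scatter), and a 4.4-fold higher number from compound 1 to compound 4 (0.64 log units; beyond the scatter). The earlier single-site step only moved a chlorine on a ring that stayed, whereas these steps show that removing the whole aromatic group also changes the result. Nothing measured here explains why the number rises. As far as these compounds go, it remains open whether the ring itself or its chlorine matters more. An unsubstituted phenyl, a cyclohexyl ring or a longer chain such as hexyl at this position could help separate the two.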